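Fluorine Added to the Weakest Diphenylacetyl Compound

This account rests on a few compounds, and the source may have more. Where it says the series, first, only, none or still open, it means among the compounds named here.

Compound 1 `O=C(O)Cc1ccc(C=C2CCN(C(=O)C(C3CCCCC3)C3CCCCC3)CC2)c(F)c1`: 7 nM
Compound 2 `O=C(O)c1ccc(C=C2CCN(C(=O)C(c3ccccc3)c3ccccc3)CC2)cc1`: 530 nM
Compound 3 `COc1cc(C(=O)O)ccc1C=C1CCN(C(=O)C(C2CCCCC2)C2CCCCC2)CC1`: 130 nM

In an assay on isolated protein for inhibition of 3-oxo-5-alpha-steroid 4-dehydrogenase 2 (Homo sapiens) (on this read-out higher numbers stand for weaker inhibition and lower numbers for stronger inhibition), compound 1 gives 7 nM and stands with the lowest number of the three. Going by the values given here, compound 3 gives 130 nM, and the single change between them, a 19-fold higher number from compound 1 to compound 3 (1.27 log units; beyond the scatter), swaps two groups at once, so the contribution of the fluoro alone cannot be read from it. Compound 2 gives 530 nM, the highest number of the set, beyond the scatter from both others.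

Compound 4 `O=C(O)c1ccc(C=C2CCN(C(=O)C(c3ccccc3)c3ccccc3)CC2)c(F)c1` differs from compound 2 by fluoro in place of hydrogen on an aromatic carbon. Among the compounds with values here, no measured pair isolates this exchange: the only step that touches a fluoro, from compound 1 to compound 3, also replaces the carboxymethyl by a carboxy and moves from fluoro to methoxy rather than to hydrogen. With the carboxy and the diphenylacetyl group of compound 2 kept unchanged, the expected step of a 1.5-fold lower number from compound 2 to compound 4 (0.18 log units; within the scatter) in this assay is small, leaning slightly toward a lower number and possibly within the scatter. Compound 4 is therefore estimated at 350 nM, with a range from 120 nM to 1100 nM.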

Compound 4, half-maximal inhibitory concentration: 410 nM
The estimate for compound 4 lay 1.2-fold (0.07 log units) below the measured number, within the range that was stated.
By their numbers in this assay, from the lowest: compound 1; then compound 3; then compounds 4 and 2 (each within the scatter of the next).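

In this assay, going by these compounds alone, the step of a 1.3-fold lower number from compound 2 to compound 4 (0.11 log units; within the scatter) is the first to isolate fluoro in place of hydrogen, here on an aromatic carbon ortho to a large group and meta to a carboxy group, with the carboxy and the two phenyl groups of the diphenylacetyl unit held unchanged. For this one pair, the change from 4-carboxyphenyl to 4-carboxy-2-fluorophenyl leaves the two numbers indistinguishable, whereas the earlier large step of a 19-fold higher number from compound 1 to compound 3 (1.27 log units; beyond the scatter) exchanged more than the fluoro and could not speak for it alone. The result comes with no accompanying measurement that could say how the fluoro behaves at this position.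

Open, as far as these compounds go, is whether a chloro or a trifluoromethyl group on the same aromatic carbon would also leave the number within the scatter, and whether fluoro would do so with the two cyclohexyl groups of compound 1 in place of the two phenyl groups. The compounds shown also leave the carboxymethyl and the carboxy unseparated, since no pair among them differs by that exchange alone.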